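Oxime ether chain length in the quinone series

The source may report more compounds than this note shows. Statements on the series, on what has been measured and on what is new or still open speak of the compounds shown alone.

The series is followed in a functional assay on A549 cells (Homo sapiens) for antiproliferative activity; a lower number here means that less compound is needed, a higher number that more compound is needed for the effect. Compound 1 `CCCCCCCCCCCCO/N=C(\CCCCCC)c1cc(OC)c2c(c1OC)C(=O)C=CC2=O` carries the longest chains of the set; in this assay compound 1 gives only the limit > 10 ug/mL and no number. Compound 3 `CCCCCC/C(=N\OCCCCC)c1cc(OC)c2c(c1OC)C(=O)C=CC2=O` keeps the heptyl of compound 1 but has a shorter chain; in this assay compound 3 likewise stops at the limit > 10 ug/mL. Compound 2 `CCCCCO/N=C/c1cc(OC)c2c(c1OC)C(=O)C=CC2=O` has hydrogen where compound 3 has heptyl; in this assay compound 2 also reaches only the limit > 10 ug/mL. Compound 2 thus stands where every value shown stands, namely at the limit of > 10 ug/mL in this assay, at which 3 of the 3 values shown sit, so its position relative to compound 1 and compound 3 cannot be ordered.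

Compound 4 `CCCCCCCCCO/N=C/c1cc(OC)c2c(c1OC)C(=O)C=CC2=O` is the not yet measured member; it differs from compound 2 by butyl in place of hydrogen on a saturated chain carbon, five bonds along the chain from an oxygen on an unsaturated carbon. Among the compounds with values here, the one measured step at this place is a step that the two limits leave unreadable from compound 1 to compound 3, and it gives neither size nor direction. Within the data shown here, no measured step therefore points to a gain for compound 4, and the step is expected as a step that the limit leaves unreadable from compound 2 to compound 4, most probably again ending at a limit. Compound 4 is estimated at 20 ug/mL in this assay, with a range from 8 ug/mL to 60 ug/mL.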

Compound 4, concentration for half-maximal effect: > 10 ug/mL
Compound 4: only a limit was reported; the forecaster's own chance of this, stated with the estimate: 85%; the middle value does not contradict the limit.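

The step between compound 2 and compound 4 cannot be read in this assay; both compounds give only a limit there, and the whole set sits at that same limit: the limit of > 10 ug/mL in this assay, at which 4 of the 4 values shown sit. The compounds shown leave open whether any chain change in the set shifts the result in this assay, in either direction, and how far each compound lies beyond the limit.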